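From Dimethylphenyl to Methoxyphenyl in a Growth Inhibition Test

The source may hold more compounds than are shown below. What is called first, only, known or untested is meant among the compounds shown, and "the series" means these compounds.

Going by the values given here, in a functional assay on DU-145 cells (Homo sapiens) for inhibition, read by trypan blue exclusion, with a stated time of 96 h (on this read-out lower numbers stand for stronger inhibition of growth and higher numbers for weaker inhibition of growth), compound 1 `Cc1cc(C)cc(/C=C(/SCc2ccc(F)cc2)C(=O)c2ccc(Br)cc2)c1` gives 10000 nM as the lowest of three numbers so far. Compound 2 `Cc1ccc(CS(=O)(=O)/C(=C/c2ccc(Br)cc2)C(=O)c2ccc(Cl)cc2)cc1` gives 25000 nM and compound 3 `O=C(/C(=C\c1ccc(O)c([N+](=O)[O-])c1)S(=O)(=O)Cc1ccc(Br)cc1)c1c(F)c(F)c(F)c(F)c1F` gives 50000 nM here, both higher than compound 1 by more than the usual scatter. Compound 4 `COc1ccc(/C=C(/SCc2ccc(F)cc2)C(=O)c2ccc(Br)cc2)cc1` has not been measured yet and differs from compound 1 in one place, with 4-methoxyphenyl in place of 3,5-dimethylphenyl on a double-bonded chain carbon bound to a double-bonded chain carbon. Among the compounds with values here, no measured pair shows this change, so the expectation is tentative. In this assay the expected step is a 2.5-fold lower number from compound 1 to compound 4 (0.40 log units; beyond the scatter) as a modest move toward stronger inhibition of growth. For compound 4 the estimated value is 4000 nM with an expected range from 1000 nM to 15000 nM in this test.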

Compound 4, concentration for 50% growth inhibition: 50000 nM
The estimate for compound 4 lay 13-fold (1.10 log units) below the measured number, outside the stated range (above it).
By their numbers in this assay, from the lowest: compound 1; then compounds 2, 3 and 4 (each within the scatter of the next).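

In this assay the group on a double-bonded chain carbon bound to a double-bonded chain carbon does matter: putting 4-methoxyphenyl in place of 3,5-dimethylphenyl gives a 5.0-fold higher number from compound 1 to compound 4 (0.70 log units; beyond the scatter) and so weaker inhibition of growth. Going by these compounds alone, this is the first single-place step in the set, and it rests on this one pair alone. Nothing measured here explains the loss.

Still open, going by these compounds, is whether the loss follows from gaining the methoxy group or from losing the two methyl groups. Also open, on these data alone, is how this position would respond to an amine or a carboxylic acid on that phenyl ring.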